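The source may hold more compounds than are shown below. What is called first, only, known or untested is meant among the compounds shown, and "the series" means these compounds.

Compound 1 `COc1cc(Cl)cc(-c2nn(-c3cccc(NC(=O)c4ccc(Cl)c(Cl)c4)c3)cc2-c2ccncc2)c1` gives the highest number among the three measured compounds in a functional assay on NCI-H460 cells (Homo sapiens) for inhibition, read by sulforhodamine B assay, with a stated time of 48 h, tested at 10 uM; a lower number here means a stronger effect, a higher number a weaker effect of the compound at the concentration tested: compound 1 reaches 65.2%, the weakest effect of the set. Its closest neighbour is compound 3 `COc1cc(Cl)cc(-c2nn(-c3cccc(NC(=O)Nc4ccc(Cl)c(Cl)c4)c3)cc2-c2ccncc2)c1`, which gives 3.1%, and the furthest is compound 2 `COc1cc(Cl)cc(-c2nn(-c3cccc(NC(=O)Nc4cc(C(F)(F)F)cc(C(F)(F)F)c4)c3)cc2-c2ccncc2)c1`, which gives 0.24%.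

Compound 4 `COc1cc(Cl)cc(-c2nn(-c3cccc(NC(=O)c4cccc(C(F)(F)F)c4)c3)cc2-c2ccncc2)c1` has not been measured. It differs from compound 1 by 3-(trifluoromethyl)phenyl in place of 3,4-dichlorophenyl on a carbonyl carbon. Among the compounds with values here, the only measured step that starts from compound 1 is a number 62.1 percentage points lower from compound 1 to compound 3 (beyond the scatter), but that step exchanges the carbonyl attachment itself rather than the aryl group on it, so it does not bear directly on the change to compound 4. Compound 2 and compound 3 share the same carbonyl attachment and differ only in the aryl group; their values in this assay lie within the scatter of each other, so an aryl swap of this kind has not yet produced a step beyond the scatter.

Compound 4 is therefore expected to stay close to compound 1, with a number 5.2 percentage points lower from compound 1 to compound 4 (within the scatter) not clearly beyond the scatter. The estimated value for compound 4 is 60%, within a range from 35% to 90%.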

Compound 4, a percentage reported as activity, at one concentration (the size of the read-out at that concentration, not a potency): 41.1%
For compound 4 the middle estimate is 18.9 percentage points above the measured one; measured number inside the range.
By their numbers in this assay, from the lowest: compounds 2 and 3 (each within the scatter of the next); then compound 4; then compound 1.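

In this assay the exchange to 3-(trifluoromethyl)phenyl in place of 3,4-dichlorophenyl on the carbonyl carbon gives a number 24.1 percentage points lower from compound 1 to compound 4 (beyond the scatter). This shows what compound 2 and compound 3 could not: the aryl group at this place can shift the read-out while the attachment to the carbonyl stays the same. The aryl exchange alone does not bring the amide up to the amino-linked compound, with a number 38 percentage points higher from compound 3 to compound 4 (beyond the scatter) in a change that alters the amino link and the ring substituents together. Nothing available here explains why either change has this effect. The compounds shown leave open how much of that larger step belongs to the amino link and how much to the ring substituents. Also open, going by these compounds, is how a cyclohexyl group or a pyridine ring would behave on this carbonyl carbon.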